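The source may hold more compounds than are shown below. What is called first, only, known or untested is meant among the compounds shown, and "the series" means these compounds.

Measured so far:
compound 1 `Cn1nc2c(=O)n(CC3(O)CCN(Cc4ccc(-c5ccco5)cc4Cl)CC3)cnc2c1-c1ccc(CNC(=O)C(F)(F)F)cc1`: 2060 nM
compound 2 `Cn1nc2c(=O)n(CC3(O)CCN(Cc4ccc(C5=CCCC5)cc4Cl)CC3)cnc2c1-c1ccc(CN)cc1`: 76.9 nM

In an assay on isolated protein for inhibition of ubiquitin carboxyl-terminal hydrolase 7 (Homo sapiens), with stated times of 30 min and 2 h (a higher number here means a weaker inhibitor, a lower number a stronger inhibitor), compound 1 gives the higher of the two numbers; compound 2 lies below it, beyond the scatter. These two differ in more than one place, so only their values are compared here.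

Compound 3 `Cn1nc2c(=O)n(CC3(O)CCN(Cc4ccc(-c5ccco5)cc4Cl)CC3)cnc2c1-c1ccc(CNC2CC2)cc1` is still unmeasured. It differs from compound 1 by cyclopropyl in place of (trifluoromethyl)carbonyl on an amine nitrogen. Going by the values given here, no single-point step between measured compounds is available for calibration. A downward step of an 8.2-fold lower number from compound 1 to compound 3 (0.92 log units; beyond the scatter) is expected in this assay. That expectation rests on compound 2, which gives 76.9 nM and shows that lower numbers are reached within the series. For compound 3 the estimate is 250 nM, with a range of 60 nM to 900 nM.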

Compound 3, half-maximal inhibitory concentration: 54.1 nM
The estimate for compound 3 lay 4.6-fold (0.66 log units) above the measured number, and the stated range ends above it.
By their numbers in this assay, from the lowest: compounds 3 and 2 (each within the scatter of the next); then compound 1.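

Going by these compounds alone, the only single-place step falls on the amine nitrogen: in this assay, cyclopropyl in place of (trifluoromethyl)carbonyl gives a 38-fold lower number from compound 1 to compound 3 (1.58 log units; beyond the scatter), so the number responds strongly to the group at this position with the rest of the structure held constant. The change removes the carbonyl and adds a three-membered ring at once, and nothing shown gives a reason for the size of the step.

From the compounds shown here alone, it remains open whether the lower number follows the loss of the trifluoromethyl, the loss of the carbonyl or the arrival of the ring. An acetyl group, an ethyl group or a plain amine at this nitrogen, with the rest of compound 3 unchanged, would separate these.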